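The compounds below may be only part of what the source reports. "The series", "measured", "known", "first", "only" and "open" are said of these compounds alone.

Measured compounds:
Compound 1 `Cc1c(C(=O)N=C(N)N)cc(S(C)(=O)=O)c(Cl)c1C` — 58 nM
Compound 2 `Cc1c(C(=O)N=C(N)N)cc(S(C)(=O)=O)c(C)c1C` — 55 nM
Compound 3 `CSc1cc(C)c(C(=O)N=C(N)N)cc1S(C)(=O)=O` — 6 nM

In a functional assay for inhibition of sodium/hydrogen exchanger (Oryctolagus cuniculus) (on this read-out higher numbers stand for weaker inhibition and lower numbers for stronger inhibition), compound 3 gives the lowest of the three numbers; compound 2 and compound 1 both give numbers beyond the scatter higher than compound 3. Within the data shown here, the one step between two measured compounds that differ in a single place, a 1.1-fold lower number from compound 1 to compound 2 (0.02 log units; within the scatter), concerns a change on a different aromatic carbon and lies within the scatter.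

Compound 4 `Cc1cc(N2CCCC(O)C2)c(S(C)(=O)=O)cc1C(=O)N=C(N)N` has not yet been measured in this assay. Its difference from compound 3 is 3-hydroxypiperidin-1-yl in place of methylsulfanyl on an aromatic carbon. No measured pair shows this change or anything like it: the only shown step swaps a methyl for a chloro, and the gap between compound 2 and compound 3 involves more than one change, so only the two values themselves can be stated. The step from compound 3 to compound 4 is therefore without a direct precedent in these data. Because compound 3 gives 6 nM, the lowest number here, the author expects some loss, with the step estimated as a 4.2-fold higher number from compound 3 to compound 4 (0.62 log units; beyond the scatter). Compound 4 is estimated at 25 nM, with a range from 5 nM to 120 nM.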

Compound 4, half-maximal inhibitory concentration: 30 nM
The estimate for compound 4 lay 1.2-fold (0.08 log units) below the measured number; low and high end bracket the measured number.
By their numbers in this assay, from the lowest: compound 3; then compounds 4, 2 and 1 (each within the scatter of the next).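

Among these compounds, at the aromatic carbon ortho to the methylsulfonyl group and para to a group of 6 heavy atoms, this assay now gives a first direct reading of a change at this position: 3-hydroxypiperidin-1-yl in place of methylsulfanyl gives a 5.0-fold higher number from compound 3 to compound 4 (0.70 log units; beyond the scatter). The step goes from a group of 2 heavy atoms without a ring to one of 7 heavy atoms with a six-membered non-aromatic ring and a hydrogen-bond donor, so this much larger group at this position comes with a modest rise in the number, though one beyond the scatter, and compound 4 still gives 30 nM. Nothing shown here accounts for the size of this step, and the data do not separate the contributions of the ring, the hydroxy group and the lost sulfur.

From the compounds shown here alone, how piperidin-1-yl without the hydroxy group would compare with compound 4 remains open. Whether an open-chain amine such as dimethylamino, or a morpholin-4-yl ring, would fall nearer to compound 3 or to compound 4 in this assay is equally unsettled.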